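Half-life after swapping pentan-3-yl for cyclopentyl

The source may report more compounds than this note shows. Statements on the series, on what has been measured and on what is new or still open speak of the compounds shown alone.

Measured in an ADME assay on microsomes from liver (Homo sapiens) for metabolic stability; a lower number here means that the compound disappears faster, a higher number that the compound lasts longer:
compound 1 `CC(C)[C@@H](c1ccc(-c2ccc3cccc(F)c3c2)[nH]c1=O)[C@@H]1OC(=O)NC1=O`: > 3 h
compound 2 `CCC(CC)C(/C=C1\OC(=O)NC1=O)c1ccc(-c2ccc3cccc(F)c3c2)[nH]c1=O`: > 3 h

Neither result is an exact number, and the record so far reads (the limit of > 3 h in this assay, at which 2 of the 2 values shown sit). Compound 2 therefore stands at a limit of the assay, > 3 h. Compound 3 `O=C1NC(=O)/C(=C/C(c2ccc(-c3ccc4cccc(F)c4c3)[nH]c2=O)C2CCCC2)O1` differs from it as follows: cyclopentyl in place of pentan-3-yl on a saturated chain carbon bound to an aromatic carbon and a double-bonded chain carbon. It carries cyclopentyl in place of pentan-3-yl on a saturated chain carbon bound to an aromatic carbon and a double-bonded chain carbon. Among the compounds with values here, no measured pair shows this swap. The estimated change, a number no higher from compound 2 to compound 3 (the limit leaves the size open), is expected to stay within the scatter, with neither direction favoured. For compound 3 the expected half-life is 3 h, with an estimated range of 1.5 h to 5 h.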

Compound 3, half-life: 1.21 h
The estimate for compound 3 lay 2.5-fold (0.39 log units) above the measured number, and the stated range ends above it.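

In this assay, the place on a saturated chain carbon bound to an aromatic carbon and a double-bonded chain carbon proves sensitive to the group it carries: cyclopentyl in place of pentan-3-yl gives an at least 2.4-fold lower number from compound 2 to compound 3 (0.39 log units; beyond the scatter). Compound 3 holds the only exact half-life shown, so this swap gives the series its first readable difference. The true size of that difference stays open, since the value of compound 2 is a limit: the limit of > 3 h in this assay, at which 2 of the 3 values shown sit.

The compounds shown leave open whether the lower number follows any ring at this place or this ring size alone. Where a cyclobutyl or cyclohexyl group would fall in this assay also remains open.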